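Carbamate replacing acetoxy on the shared core

A few compounds are considered here, and "the series" means these few. Any claim that something is new, unique, unknown or untested is made for them only; others in the source may bear on it.

Compound 3 `CC(=O)Oc1ccc2c(c1)C(n1ccccc1=O)=CC(C)(C)O2` gives 4.97 in a functional assay (trachea) with Rattus norvegicus as the target (a higher number here means a more potent compound, by a factor of ten per unit of this negative logarithm, a lower number a less potent compound), the lowest of the three numbers in hand; compound 1 `CC1(C)C=C(n2ccccc2=O)c2cc(C(=O)c3ccccc3)ccc2O1` gives 6.21 and compound 2 `CC1(C)C=C(n2ccccc2=O)c2cc(C(=O)c3ccccc3F)ccc2O1` gives 6.34. The drop a number 1.24 log units lower from compound 1 to compound 3 (beyond the scatter) and the drop a number 1.37 log units lower from compound 2 to compound 3 (beyond the scatter) are both large, whereas a number 0.13 log units higher from compound 1 to compound 2 (within the scatter) is not. Compound 4 `CC1(C)C=C(n2ccccc2=O)c2cc(OC(=O)Nc3ccc(C(F)(F)F)cc3)ccc2O1` differs from compound 3 by (4-(trifluoromethyl)phenyl)amino in place of methyl on a carbonyl carbon. Among the measured compounds shown here, no measured step touches a carbonyl carbon, so none bears directly on this change; the large losses into compound 3 only show that this position on the core is sensitive. A moderate upward step is expected, but with wide uncertainty, so compound 4 is estimated at 5.6, between 4.8 and 6.5, meaning an expected a number 0.63 log units higher from compound 3 to compound 4 (beyond the scatter).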

Compound 4, logarithm of the reciprocal of the active concentration, log(1/C): 4.54
Estimate against measurement, compound 4: 1.06 log units above, and the stated range ends above it.
By their numbers in this assay, from the lowest: compound 4; then compound 3; then compounds 1 and 2 (each within the scatter of the next).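

In this assay, (4-(trifluoromethyl)phenyl)amino in place of methyl on the carbonyl carbon gives a number 0.43 log units lower from compound 3 to compound 4 (beyond the scatter). Among the compounds shown here, this is the first reading at this carbonyl carbon: the much larger group, with its aromatic ring and hydrogen-bond donor, brings no gain and costs only a modest loss. No supporting measurement bears on why the number falls.

The compounds shown leave open whether the trifluoromethyl group, the ring or the hydrogen on nitrogen drives the step. Plain phenylamino or dimethylamino on the same carbonyl carbon would separate these.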